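One Ring Exchanged, Cell Toxicity Expected Unchanged

The source may hold more compounds than are shown below. What is called first, only, known or untested is meant among the compounds shown, and "the series" means these compounds.

Of the compounds shown here, three have so far been measured in an ADME assay on HEp-2 cells (Homo sapiens) for cytotoxicity, read by trypan blue exclusion, with a stated time of 24 h; on this read-out lower numbers stand for higher toxicity in this test and higher numbers for lower toxicity in this test. Compound 1 `C/C(=N\N=C1/SCC(=O)N1Cc1cccc(F)c1)c1cccs1` gives 6 ug/mL, compound 2 `C/C(=N/N=C1\SCC(=O)N1Cc1ccc(F)cc1)c1cccs1` gives 15 ug/mL, and compound 3 `C/C(=N/N=C1\SCC(=O)N1Cc1ccccc1[N+](=O)[O-])c1cccs1` gives 20 ug/mL. Compound 2 stands second highest of these three numbers: its gap to compound 3 lies within the usual scatter, while its number sits beyond the scatter below that of compound 1. Compound 4 `C/C(=N/N=C1\SCC(=O)N1Cc1ccc(F)cc1)c1ccccn1` has not yet been measured. It differs from compound 2 in one place: pyridin-2-yl in place of thiophen-2-yl on a carbon with a double bond to nitrogen. Within the data shown here, no measured pair shows this change, so nothing here points toward a step in either direction. In this assay the expected step is no change at the digits printed from compound 2 to compound 4 (within the scatter), none beyond the scatter. Compound 4 is therefore estimated at 15 ug/mL, within 7 ug/mL to 35 ug/mL.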

Compound 4, half-maximal cytotoxic concentration in the HEp-2 assay: 16 ug/mL
Beside the measured number, compound 4's estimate is 1.1-fold (0.03 log units) below it; measured number inside the range.
By their numbers in the HEp-2 assay, from the lowest: compound 1; then compounds 2, 4 and 3 (each within the scatter of the next).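

In the HEp-2 assay the exchange of thiophen-2-yl for pyridin-2-yl on this carbon gives a 1.1-fold higher number from compound 2 to compound 4 (0.03 log units; within the scatter) and so shows that a six-membered aromatic ring can stand here in place of a five-membered one with no step beyond the scatter. In a physicochemical assay, with a stated time of 90 min (a higher number here means that more compound is needed for the effect, a lower number that less compound is needed), compound 2 gives 1370000 nM and compound 4 gives 1160000 nM and the step, a 1.2-fold lower number from compound 2 to compound 4 (0.07 log units; within the scatter), again stays within the scatter. Nothing measured here gives a reason for either result. Still open, from the compounds shown here alone, is whether an amine or a carboxylic acid on this carbon would also leave both numbers within the scatter.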